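Series notes: varying the amino substituent on the shared core

The compounds below may be only part of what the source reports. "The series", "measured", "known", "first", "only" and "open" are said of these compounds alone.

Measured compounds:
compound 1 `CC(C)c1n[nH]c2c(NCc3ccc(-c4ccccn4)cc3)nc(NCCO)nc12` — 51 nM
compound 2 `CC(C)c1n[nH]c2c(NCc3ccc(-c4ccccn4)cc3)nc(N3CCNCC3)nc12` — 21 nM

For the measured compounds named here, in a functional assay on MCF7 cells (Homo sapiens) for cytotoxicity, read by fluorescence, with a stated time of 72 h (on this read-out higher numbers stand for weaker inhibition and lower numbers for stronger inhibition), compound 1 gives 51 nM, the highest of the two numbers measured so far; in this assay compound 2 gives 21 nM. Going by the values given here, the one measured step, a 2.4-fold lower number from compound 1 to compound 2 (0.39 log units; beyond the scatter), is the only comparison available and it lies beyond the scatter.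

Compound 3 `CC(C)c1n[nH]c2c(NCc3ccc(-c4ccccn4)cc3)nc(N[C@H]3CC[C@H](N)CC3)nc12` is not yet measured in this assay. It differs from compound 1 as follows: 4-aminocyclohexyl in place of 2-hydroxyethyl on a nitrogen on an aromatic ring. The step from compound 1 to compound 2 bears on this change, since there too the (2-hydroxyethyl)amino group on the shared core gave way to a larger, ring-containing amine, and the number fell modestly. The change to compound 3 is a different group, so the size of any step is uncertain, but a modest fall in the number, in the same direction, is the expectation that the data support.

Compound 3 is therefore expected to give 25 nM in this assay, within 10 nM to 70 nM, an expected step of a 2.0-fold lower number from compound 1 to compound 3 (0.31 log units; beyond the scatter).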

Compound 3, half-maximal inhibitory concentration: 474 nM
Estimate against measurement, compound 3: 19-fold (1.28 log units) below, outside the stated range (above it).
By their numbers in this assay, from the lowest: compound 2; then compound 1; then compound 3.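

In this assay, 4-aminocyclohexyl in place of 2-hydroxyethyl on a nitrogen on an aromatic ring gives a 9.3-fold higher number from compound 1 to compound 3 (0.97 log units; beyond the scatter), so across these three compounds a ring-containing amine at this position does not by itself bring a lower number; compound 2 fits that idea and compound 3 goes against it. The comparison between the two ring-containing amines is the widest in the set: (4-aminocyclohexyl)amino in place of piperazin-1-yl on an aromatic carbon gives a 23-fold higher number from compound 2 to compound 3 (1.35 log units; beyond the scatter), which shows that the identity of the amine, rather than the presence of a ring, goes with the direction and size of the step in these compounds. No measurement at hand bears on the reason for this reversal.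

The compounds shown leave open whether the higher number of compound 3 goes with the cyclohexyl ring or with the amino group on it, a question that a plain cyclohexyl group or a 4-hydroxycyclohexyl group on the same nitrogen would address. Also open, from the compounds shown here alone, is how far the result depends on the defined stereocentres of the 4-aminocyclohexyl group, which the opposite arrangement of that amine on the ring would test.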